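Trading an Aryl Group for a Pentyl Chain

The source may report more compounds than this note shows. Statements on the series, on what has been measured and on what is new or still open speak of the compounds shown alone.

Compound 1 `COc1cccc(-c2nc3c(-c4cccc(Cl)c4)n[nH]c3c(=O)n2NC(=O)c2ccccc2)c1` gives 93.5%.
Compound 2 `COc1cccc(-c2nc3c(-c4ccc(Cl)cc4)n[nH]c3c(=O)n2NC(=O)c2ccccc2)c1` gives 94.1%.
Compound 3 `COc1cccc(-c2nc3c(-c4ccco4)n[nH]c3c(=O)n2NC(=O)c2ccccc2)c1` gives 50.5%.

In a functional assay on DU-145 cells (Homo sapiens) for cytotoxicity, read by sulforhodamine B assay, with a stated time of 2 days, tested at 100 uM (on this read-out lower numbers stand for less inhibition and higher numbers for more inhibition at the one concentration tested (going by the name of the read-out)), compound 2 holds the highest of the three numbers. Its nearest neighbour is compound 1, since the step of a number 0.6 percentage points higher from compound 1 to compound 2 (within the scatter) lies within the scatter; its furthest is compound 3, since the step of a number 43.6 percentage points lower from compound 2 to compound 3 (beyond the scatter) lies well beyond it. Compound 4 `CCCCCc1nc2c(-c3ccc(Cl)cc3)n[nH]c2c(=O)n1NC(=O)c1ccccc1` differs from compound 2 in one place: pentyl in place of 3-methoxyphenyl on an aromatic carbon. Neither measured step bears directly on this change, because the steps of a number 43 percentage points lower from compound 1 to compound 3 (beyond the scatter) and a number 43.6 percentage points lower from compound 2 to compound 3 (beyond the scatter) alter a different group on the shared core. With no guide, a moderate decrease is expected, as the step of a number 29.1 percentage points lower from compound 2 to compound 4 (beyond the scatter). Compound 4 is therefore estimated at 65%, within a wide range from 30% to 95%.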

Compound 4, a percentage reported as inhibition, at one concentration (the size of the read-out at that concentration, not a potency): 88.7%
The estimate for compound 4 lay 23.7 percentage points below the measured number, and the stated range covers the measured number.
By their numbers in this assay, from the lowest: compound 3; then compounds 4, 1 and 2 (each within the scatter of the next).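

In this assay, the carbon between two ring nitrogen atoms carries a pentyl chain in place of 3-methoxyphenyl with a number 5.4 percentage points lower from compound 2 to compound 4 (within the scatter), so for this pair an aromatic ring at this position is not required to keep the number high. Among these compounds, the earlier compounds changed only a different group on the shared core, so this is the first view of this position. Nothing measured here explains this result. Still open, from the compounds shown here alone, is whether a shorter chain such as methyl, an amine or a carboxylic acid would fit here, and whether pentyl would give a similar number with furan-2-yl at the other position.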